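The source may report more compounds than this note shows. Statements on the series, on what has been measured and on what is new or still open speak of the compounds shown alone.

Working notes on a set of cyclic nucleotide analogues sharing one core. For the measured compounds named here, compound 1 `CSc1nc2c(N)ncnc2n1[C@@H]1O[C@@H]2COP(=O)(O)O[C@H]2[C@H]1O` is the only member with a number so far: in a functional assay on the whole organism for activation, with Mus musculus as the target, with stated times of 14 days and 2 h, at a dose of 30 mg/kg by the intravenous route (a higher number here means a stronger effect of the compound at the dose given, a lower number a weaker effect), compound 1 gives 804%. Compound 2 `Nc1ncnc2c1nc(O)n2[C@@H]1O[C@@H]2COP(=O)(O)O[C@H]2[C@H]1O` in this assay stands at no result reported. Going by the values given here, compound 3 `Nc1ncnc2c1nc(S)n2[C@@H]1O[C@@H]2COP(=O)(O)O[C@H]2[C@H]1O` likewise in this assay stands at no result reported; a second member of the series, compound 2, shares that gap, so compound 3 cannot be placed against any measured neighbour, and no step between measured compounds exists in this set.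

The next compound, compound 4 `Nc1ncnc2c1nc(N)n2[C@@H]1O[C@@H]2COP(=O)(O)O[C@H]2[C@H]1O`, differs from compound 3 in one place: amino in place of sulfanyl on an aromatic carbon. With compound 3 unmeasured, the size of the step in this assay cannot be anchored; given only compound 1 at 804% as a reference for the series, no direction is expected beyond the scatter, and the estimate rests on that single point with a wide range. Compound 4 is expected to give 400% in this assay, within 50% to 1000%.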

Compound 4, a percentage reported as activity, at one dose (the size of the read-out at that dose, not a potency): 607%
Estimate against measurement, compound 4: 207 percentage points below; the measured number falls inside the stated range.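

For the compounds shown here, on the aromatic carbon between two ring nitrogen atoms, amino in place of methylsulfanyl gives the first readable change in this assay: a number 197 percentage points lower from compound 1 to compound 4 (beyond the scatter), a step beyond the usual scatter. The group at this position therefore affects the read-out, although compound 4 at 607% retains a sizeable percentage with the amino group in place. No measured data bear on what underlies the difference between these two groups.

Steps involving compound 2 or compound 3 cannot be read, as neither has a single number, so the hydroxyl and sulfanyl groups remain unplaced against amino and methylsulfanyl. Also open, from the compounds shown here alone, is how a longer chain on the sulfur, such as benzylsulfanyl, or a dimethylamino group at the same position would compare with compound 1 and compound 4.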